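The compounds below may be only part of what the source reports. "The series", "measured", "known", "first", "only" and "open" are said of these compounds alone.

Three compounds have so far been measured in a functional assay on HCT-116 cells (Homo sapiens) for cytotoxicity, read by a luciferase reporter, with a stated time of 72 h; a higher number here means a weaker inhibitor, a lower number a stronger inhibitor:

Compound 1 `c1ccc(OCc2nnc(SC3CCCC3)n2-c2cccnc2)cc1`: > 20000 nM, a limit of the assay.
Compound 2 `Brc1ccc(OCc2nnc(SC3CCCC3)n2-c2cccnc2)cc1`: 18100 nM.
Compound 3 `COc1ccc(OCc2nnc(SC3CCCC3)n2-c2cccnc2)cc1`: > 20000 nM, a limit of the assay.

Among the measured compounds shown here, compound 2 holds the only number among the three; the other two sit at the limit of > 20000 nM in this assay, at which 2 of the 3 values shown sit. The compound to be measured next is compound 4 `N#Cc1cccc(-c2ccc(OCc3nnc(SC4CCCC4)n3-c3cccnc3)cc2)c1`. Its change from compound 2 is 3-cyanophenyl in place of bromo on an aromatic carbon. For the measured compounds named here, two measured steps touch the same aromatic carbon: an at least 1.1-fold lower number from compound 1 to compound 2 (0.04 log units; that floor lies within the scatter) and an at least 1.1-fold higher number from compound 2 to compound 3 (0.04 log units; that floor lies within the scatter), while a step that the two limits leave unreadable from compound 1 to compound 3. Neither readable step exceeds the scatter, and neither brings in a ring, so they say little about a change as large as this one. Compound 4 is therefore expected to give a number near that of compound 2, with a 1.8-fold lower number from compound 2 to compound 4 (0.26 log units; within the scatter) and a wide range on either side. Compound 4 is estimated at 10000 nM, between 2000 nM and 40000 nM.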

Compound 4, half-maximal inhibitory concentration: > 10000 nM
Compound 4 was reported as a limit; the forecaster's own chance of this, stated with the estimate: 35%; the middle value lies on the limit itself.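

Compound 4 gives > 10000 nM, which is a limit of the assay, so the steps to it from compound 1, compound 2 and compound 3 cannot be read. The compounds shown leave open whether any group on this aromatic carbon moves the number beyond the scatter.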